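This account rests on a few compounds, and the source may have more. Where it says the series, first, only, none or still open, it means among the compounds named here.

Measured so far:
compound 1 `COc1cc(/C=C/C(=O)c2cccc(-n3cc(-c4ccccc4)[nH]c3=O)c2)cc(OC)c1OC` — 2190 nM
compound 2 `COc1ccc(-c2cn(-c3cccc(C(=O)/C=C/c4ccc(O)c(OC)c4)c3)c(=O)[nH]2)cc1` — 3600 nM

In a functional assay on T47D cells (Homo sapiens) for inhibition (on this read-out lower numbers stand for stronger inhibition of growth and higher numbers for weaker inhibition of growth), compound 2 gives 3600 nM, the higher of the two numbers recorded, with compound 1 as its only comparator at 2190 nM; the gap between the two lies within the scatter, so no order can be read from them.

Compound 3 `COc1ccc(-c2cn(-c3cccc(C(=O)/C=C/c4cc(OC)c(OC)c(OC)c4)c3)c(=O)[nH]2)cc1` has not yet been measured in this assay. It differs from compound 2 in one place: 3,4,5-trimethoxyphenyl in place of 4-hydroxy-3-methoxyphenyl on a double-bonded chain carbon bound to a double-bonded chain carbon. Going by the values given here, the 3,4,5-trimethoxyphenyl group that enters is the one already present in compound 1, which gives 2190 nM in this assay, so the change has a reference point, though no direct pair of measured compounds isolates it.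

The step from compound 2 to compound 3 is therefore expected to be small, at most a modest move toward a lower number, a 1.4-fold lower number from compound 2 to compound 3 (0.16 log units; within the scatter), and plausibly none beyond the scatter. Compound 3 is estimated at 2500 nM, with a range from 900 nM to 7000 nM.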

Compound 3, concentration for 50% growth inhibition: 3840 nM
The estimate for compound 3 lay 1.5-fold (0.19 log units) below the measured number, and the stated range covers the measured number.
By their numbers in this assay, from the lowest: compounds 1, 2 and 3 (each within the scatter of the next).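

In this assay, going by these compounds alone, 3,4,5-trimethoxyphenyl in place of 4-hydroxy-3-methoxyphenyl gives a 1.1-fold higher number from compound 2 to compound 3 (0.03 log units; within the scatter) and so provides the first direct pair at this position: the hydrogen-bond donor of the leaving group can go and two further methoxy-bearing sites can come without a step beyond the scatter. Methoxy in place of hydrogen on an aromatic carbon, a change in another place, gives a 1.8-fold higher number from compound 1 to compound 3 (0.24 log units; within the scatter) and likewise stays inside the scatter, so neither change has a readable effect here. No independent measurement bears on these results.

Going by these compounds, whether an amine or a carboxylic acid on this phenyl ring would move the number beyond the scatter remains open. On these data alone, the methoxy step is also known only with 3,4,5-trimethoxyphenyl in place, so its size with 4-hydroxy-3-methoxyphenyl remains open too.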